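The source may report more compounds than this note shows. Statements on the series, on what has been measured and on what is new or still open speak of the compounds shown alone.

Working notes on a set of arylpiperazine oxime ethers tested in a functional assay on HEK293 cells with D(4) dopamine receptor (Homo sapiens) as the target, read by FLIPR; a lower number here means a smaller maximal response, a higher number a larger maximal response. Compound 1 `CCCO/N=C(\CCN1CCN(c2ccccn2)CC1)c1ccccc1` gives 64%. Compound 2 `O/N=C(\CCN1CCN(c2ncccn2)CC1)c1ccccc1` gives 49%. Compound 3 `CCO/N=C(\CCN1CCN(c2ccccc2)CC1)c1ccccc1` gives 80%, the largest maximal response of the three: its number lies beyond the scatter above that of compound 1 and further still above that of compound 2. Among the measured compounds shown here, no single-point step between measured compounds is available, so the series offers no measured guide for the next change.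

Compound 4 `CCO/N=C(\CCN1CCN(c2ccccc2OC)CC1)c1ccccc1` is the not-yet-measured neighbour of compound 3. It differs by methoxy in place of hydrogen on an aromatic carbon, which, taken one bond further out, reads phenyl to 2-methoxyphenyl. Nothing in the measured numbers speaks for or against this change; with compound 3 already at the top of the set, an upward step of any size is less likely than a flat or downward one. The expected step in this assay from compound 3 to compound 4 is a number 10 percentage points lower from compound 3 to compound 4 (within the scatter), a small step, possibly within the scatter. Compound 4 is therefore estimated at 70%, expected between 45% and 95%.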

Compound 4, largest response reached (reported as efficacy), in percent of the reference or control that the assay uses: 76%
Beside the measured number, compound 4's estimate is 6 percentage points below it; the range from low to high includes it.
By their numbers in this assay, from the lowest: compound 2; then compound 1; then compounds 4 and 3 (each within the scatter of the next).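

In this assay, among the compounds shown here, methoxy in place of hydrogen on an aromatic carbon, ortho to a large group, gives a number 4 percentage points lower from compound 3 to compound 4 (within the scatter), the first step that changes only one place. The maximal response therefore shows no readable change when phenyl becomes 2-methoxyphenyl, so this position accepts methoxy with the ethyl oxime ether held constant. No measured evidence bears on why this step is so small.

From the compounds shown here alone, it remains open whether this tolerance extends to other groups at the same position, such as a primary amine, a carboxylic acid or a longer ethoxy chain. Also open, going by these compounds, is whether methoxy behaves the same way on the other aromatic carbons of this ring, or alongside a different oxime ether.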